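Enamine ketone series: indolyl amine replacement on compound 2

The source may report more compounds than this note shows. Statements on the series, on what has been measured and on what is new or still open speak of the compounds shown alone.

Compound 1 `O=C(/C=C\Nc1ccc(F)cc1)c1nc(-c2ccc(F)cc2)n2ccccc12` — in a functional assay on B16-F10 cells (Mus musculus) for cytotoxicity, read by MTT assay, with a stated time of 48 h (on this read-out lower numbers stand for stronger inhibition and higher numbers for weaker inhibition), compound 1 reaches only the assay limit, > 30000 nM.
Compound 2 `O=C(/C=C\Nc1ccc(Cl)cc1)c1nc(-c2ccc(F)cc2)n2ccccc12` — in this assay compound 2 gives 11000 nM.

Among the compounds with values here, compound 2 holds the only numerical value in this assay; the other entry is a limit, not a number. Within the data shown here, the single measured step, an at least 2.7-fold lower number from compound 1 to compound 2 (0.43 log units; beyond the scatter), lies beyond the scatter, but its true size is open since it rests on (the limit of > 30000 nM in this assay, at which 1 of the 2 values shown sits).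

Compound 3 `Cc1cc2cc(N/C=C\C(=O)c3nc(-c4ccc(F)cc4)n4ccccc34)ccc2[nH]1` differs from compound 2 by 2-methyl-1H-indol-5-yl in place of 4-chlorophenyl on an amine nitrogen. Among the measured compounds shown here, no measured step bears directly on this change: the one measured step exchanges a halogen for another halogen on an aromatic carbon, whereas here the whole aryl group on the amine nitrogen is replaced by a bicyclic group carrying a hydrogen-bond donor. The step expected here, a 1.8-fold lower number from compound 2 to compound 3 (0.26 log units; within the scatter), is accordingly small and uncertain in direction. Compound 3 is estimated at 6000 nM, with a range from 1500 nM to 25000 nM.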

Compound 3, half-maximal inhibitory concentration: > 30000 nM
Compound 3 ended at the assay's limit; the forecaster's own chance of this, stated with the estimate: 15%; middle value at least 5.0-fold (0.69 log units) from the limit.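

At the amine nitrogen, the change from 4-chlorophenyl to 2-methyl-1H-indol-5-yl gives an at least 2.7-fold higher number from compound 2 to compound 3 (0.43 log units; beyond the scatter) and so does not keep the measured activity of compound 2, which the halogen exchange alone could not show. Compound 3 gives > 30000 nM in this assay and this is a limit, not a number. As far as these compounds go, the step between compound 1 and compound 3 cannot be read, as both ends are limits, and the true size of the step to compound 3 also stays open: (the limit of > 30000 nM in this assay, at which 2 of the 3 values shown sit).

The compounds shown do not separate the part of the methyl group from that of the indole ring itself. They also leave open how a 4-bromophenyl or 4-methoxyphenyl group on the amine nitrogen would read against compound 2.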